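Cytotoxicity of a Benzylimidazole Aniline Series in Fibroblasts

A few compounds are considered here, and "the series" means these few. Any claim that something is new, unique, unknown or untested is made for them only; others in the source may bear on it.

Measured compounds in a toxicity assay on NIH3T3 cells (Mus musculus) for cytotoxicity, read by resazurin assay; on this read-out lower numbers stand for an effect already at smaller amounts and higher numbers for an effect only at larger amounts of compound:
- compound 1 `COC(=O)c1ccc(NCc2cncn2Cc2ccccc2Cl)cc1-c1ccccc1`: 10000 nM
- compound 2 `Cc1ccccc1-c1cc(NCc2cncn2Cc2ccc(-c3ccccc3)cc2)ccc1-c1nc2ccccc2s1`: the assay reports only a limit, > 1000 nM
- compound 3 `CCc1ccc(Cn2cncc2CNc2ccc(-c3nc4ccccc4s3)c(-c3ccccc3)c2)cc1`: the assay reports only a limit, > 1000 nM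

Compound 1 is the only one of the three for which this assay returns a number; the other two values sit at the limit of the assay (the limit of > 1000 nM in this assay, at which 2 of the 3 values shown sit), so compound 1 cannot be placed above or below them. Compound 2 and compound 3 share a different core and are not connected to compound 1 by a single change, so their limits say only that no effect was seen up to that concentration.

Compound 4 `COC(=O)c1ccc(NCc2cncn2Cc2cccc(C(C)(C)C)c2)cc1-c1ccccc1` has not yet been tested. Relative to compound 1 it carries 3-(tert-butyl)phenyl in place of 2-chlorophenyl on a saturated chain carbon bound to an aromatic nitrogen. For the measured compounds named here, no measured pair in this set tracks such a change, so the expectation rests on compound 1 alone. The author expects the step of a 1.3-fold lower number from compound 1 to compound 4 (0.10 log units; within the scatter) to stay within the usual scatter, with at most a modest shift toward an effect at smaller amounts. Compound 4 is therefore estimated at 8000 nM in this assay, within a range from 2500 nM to 30000 nM, and there remains a fair chance the assay returns only a limit.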

Compound 4, half-maximal effective concentration: > 1000 nM
Compound 4: a limit, no number; the forecaster's own chance of this, stated with the estimate: 40%; the middle value does not contradict the limit.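

Compound 4 returns only a limit, so the step from compound 1 to compound 4 cannot be read, and the value of compound 1 cannot be set against it: the limit of > 1000 nM in this assay, at which 3 of the 4 values shown sit. The compounds shown leave open whether 3-(tert-butyl)phenyl in place of 2-chlorophenyl shifts the read-out at all, and in which direction.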